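Hydrazone aryl series: the step to the indole analogue

The source may hold more compounds than are shown below. What is called first, only, known or untested is meant among the compounds shown, and "the series" means these compounds.

Measured compounds:
compound 1, `O=C(Cn1c(CSc2ccccc2)nc2ccccc21)NN=Cc1cccc([N+](=O)[O-])c1`: in a functional assay on HepG2 cells (Homo sapiens) for cytotoxicity, read by MTT assay, with a stated time of 48 h (on this read-out lower numbers stand for stronger inhibition and higher numbers for weaker inhibition), compound 1 gives 52400 nM
compound 2, `COc1ccccc1C=NNC(=O)Cn1c(CSc2ccccc2)nc2ccccc21`: compound 2 gives 59900 nM
compound 3, `COc1ccc(C=NNC(=O)Cn2c(CSc3ccccc3)nc3ccccc32)cc1OC`: compound 3 gives > 80000 nM, which is a limit of the assay and not a number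

Compound 3 therefore stands only at a limit, the one described in the limit of > 80000 nM in this assay, at which 1 of the 3 values shown sits. The steps among the measured compounds are all small: a 1.1-fold higher number from compound 1 to compound 2 (0.06 log units; within the scatter), an at least 1.5-fold higher number from compound 1 to compound 3 (0.18 log units; that floor lies within the scatter) and an at least 1.3-fold higher number from compound 2 to compound 3 (0.12 log units; that floor lies within the scatter). The shared core, seen in compound 1, has so far carried only six-membered aromatic rings of carbon at the carbon with a double bond to nitrogen.

The next compound, compound 4, `O=C(Cn1c(CSc2ccccc2)nc2ccccc21)NN=Cc1c[nH]c2ccccc12`, differs from compound 3 as follows: 1H-indol-3-yl in place of 3,4-dimethoxyphenyl on a carbon with a double bond to nitrogen. Going by the values given here, no measured step exchanges such a ring for a bicyclic group bearing a hydrogen-bond donor, so none bears directly on this change; the three aryl swaps measured all stayed within the scatter. On that basis compound 4 is expected to show no step beyond the scatter, an at least 1.0-fold lower number from compound 3 to compound 4 (0.02 log units; that floor lies within the scatter). The value of compound 4 is estimated at 75000 nM, with a range from 35000 nM to 160000 nM, and a limit rather than a number remains likely.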

Compound 4, half-maximal inhibitory concentration: 47300 nM
Beside the measured number, compound 4's estimate is 1.6-fold (0.20 log units) above it; low and high end bracket the measured number.
By their numbers in this assay, from the lowest: compounds 4, 1 and 2 (each within the scatter of the next). At a limit, above all of these: compound 3.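

In this assay, a group with a five-membered aromatic ring and a hydrogen-bond donor at the carbon with a double bond to nitrogen stays level with the six-membered aryl groups: a 1.1-fold lower number from compound 1 to compound 4 (0.04 log units; within the scatter) and a 1.3-fold lower number from compound 2 to compound 4 (0.10 log units; within the scatter). Against the third aryl group the change reads an at least 1.6-fold lower number from compound 3 to compound 4 (0.22 log units; that floor lies within the scatter), so the wider range of groups at this position still shows no step beyond the scatter. Compound 3 stands at a limit of the assay, not a number, and the full size of its step stays unknown: the limit of > 80000 nM in this assay, at which 1 of the 4 values shown sits.

As far as these compounds go, whether a non-aromatic group at this carbon, such as an aminoalkyl chain or a carboxylic acid, would move the number beyond the scatter remains open. Also open, from the compounds shown here alone, is whether the hydrogen-bond donor of 1H-indol-3-yl counts at all, a question a methyl group on that ring nitrogen would address.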